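A few compounds are considered here, and "the series" means these few. Any claim that something is new, unique, unknown or untested is made for them only; others in the source may bear on it.

Measured so far:
compound 1 `CC(C)OC(=O)C1=C(C(F)(F)F)NC(=O)NC1c1ccsc1`: 3%
compound 2 `CCOC(=O)C1=C(C(F)(F)F)NC(=O)NC1c1ccsc1`: 3%

In an assay on HeLa cells for displacement of a labelled ligand from adenosine receptor A3 (Homo sapiens), read by radioligand binding, with a stated time of 180 min, tested at 1 uM (on this read-out lower numbers stand for less inhibition and higher numbers for more inhibition at the one concentration tested (going by the name of the read-out)), compound 1 gives 3% and compound 2 gives 3%. Compound 1 stands level with compound 2 at the digits shown, both near the bottom of the read-out, with compound 2 its nearest neighbour. For the measured compounds named here, the single recorded step, no change at the digits printed from compound 1 to compound 2 (within the scatter), covers hydrogen in place of methyl on a saturated chain carbon bound to an oxygen next to a carbonyl group and a saturated chain carbon; the ester end of the shared core can be varied without any movement in this assay.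

Compound 3 `CC(C)OC(=O)C1=C(C(F)(F)F)NC(=O)NC1c1cccs1` is not yet measured. It differs from compound 1 by thiophen-2-yl in place of thiophen-3-yl on a saturated ring carbon. Going by the values given here, no measured step touches the thiophene position, so the exchange has no direct precedent; what is known is only that compound 1 and compound 2 both sit low and that the one recorded step left the read-out unmoved. The expectation for this assay is therefore a step of a number 1 percentage points higher from compound 1 to compound 3 (within the scatter), that is none beyond the scatter. Compound 3 is estimated at 4%. The range expected for compound 3 runs from -5% to 15%.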

Compound 3, a percentage reported as inhibition, at one concentration (the size of the read-out at that concentration, not a potency): 7%
Beside the measured number, compound 3's estimate is 3 percentage points below it; low and high end bracket the measured number.
By their numbers in this assay, from the lowest: compounds 1, 2 and 3 (each within the scatter of the next).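

The thiophene position, which the earlier ester step did not touch, now has a reading of its own: in this assay, thiophen-2-yl in place of thiophen-3-yl on a saturated ring carbon gives a number 4 percentage points higher from compound 1 to compound 3 (within the scatter) and so stays within the scatter. Changing only how the thiophene is joined to the shared core, with the same heavy atoms in the group and the same hydrogen-bond counts, therefore does not take the series away from the low end of the read-out, where compound 3 at 7% still sits. No available evidence bears on why the two thiophene attachments read alike.

The compounds shown give no reading at this ring carbon for anything other than the two thiophenes, so it remains open whether a phenyl ring, a pyridine ring or a thiophene carrying an amine would leave the low end of the read-out. Also open, on these data alone, is whether a carboxylic acid or a longer chain at the ester end, or a methyl group in place of trifluoromethyl, would move the series in this assay.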